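Swapping the Phenyl Group of Compound 3

The source may report more compounds than this note shows. Statements on the series, on what has been measured and on what is new or still open speak of the compounds shown alone.

In a functional assay on Jurkat cells (Homo sapiens) for inhibition, read by CCK-8 assay, with a stated time of 48 h (on this read-out lower numbers stand for stronger inhibition of growth and higher numbers for weaker inhibition of growth), compound 3 (`CN1CCN(c2ccc(Nc3ncc(Cl)c(Nc4ccc(C(C)(C)C)cc4)n3)nc2)CC1`) offers no number to start from, its result being "not determined" (no result reported) here. Compound 4 (`Cc1cc(C)c(Nc2nc(Nc3ccc(N4CCN(C)CC4)cn3)ncc2Cl)c(C)c1`) carries 2,4,6-trimethylphenyl in place of 4-(tert-butyl)phenyl on a nitrogen on an aromatic ring. The nearest evidence begins with compound 1 (`CN1CCN(c2ccc(Nc3ncc(Cl)c(NCc4ccccc4)n3)nc2)CC1`), whose > 100000 nM is a limit of the assay and not a number. Compound 2 (`Cc1cccc(Nc2nc(Nc3ccc(N4CCN(C)CC4)cn3)ncc2Cl)c1`) gives 15300 nM with 3-methylphenyl on that nitrogen. Among the compounds with values here, replacing benzyl this way produced an at least 6.5-fold lower number from compound 1 to compound 2 (0.81 log units; beyond the scatter) in the only measured step. Compound 4 also has a methyl-bearing phenyl there, so a result near compound 2 at 15300 nM is expected, with no step beyond the scatter. For compound 4 the estimated value is 18000 nM in this assay, with an expected range from 6000 nM to 60000 nM as its ends.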

Compound 4, concentration for 50% growth inhibition: 7600 nM
Compound 4: middle estimate off by 2.4-fold (0.37 log units), on the high side, within the range that was stated.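

Compound 4 shows that, on this nitrogen, three methyl groups on the phenyl ring read no differently from one in this assay, since a 2.0-fold lower number from compound 2 to compound 4 (0.30 log units; within the scatter) stays within the scatter. Set against benzyl, the change is much clearer, with an at least 13-fold lower number from compound 1 to compound 4 (1.11 log units; beyond the scatter). The compound 1 end of that step is a limit of the assay and not a number: the limit of > 100000 nM in this assay, at which 1 of the 4 values shown sits.

With no result for compound 3, 4-(tert-butyl)phenyl offers no comparison with 2,4,6-trimethylphenyl. From the compounds shown here alone, how a phenyl ring carrying an amine or a carboxylic acid would read at this nitrogen remains open.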